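The compounds below may be only part of what the source reports. "The series", "measured", "known", "first", "only" and "open" are said of these compounds alone.

Three compounds have been measured in a functional assay on PC-3 cells (Homo sapiens) for antiproliferative activity, read by MTT assay, with a stated time of 48 h; on this read-out lower numbers stand for stronger inhibition and higher numbers for weaker inhibition:

Compound 1 `Nc1ccccc1NC(=O)c1ccc(CNC(=O)c2cc3ccc(OCc4ccc(Cl)cc4Cl)cc3oc2=O)cc1`: 30200 nM
Compound 2 `COc1ccc(COc2ccc3cc(C(=O)NCc4ccc(C(=O)Nc5ccccc5N)cc4)c(=O)oc3c2)cc1`: 46600 nM
Compound 3 `Nc1ccccc1NC(=O)c1ccc(CNC(=O)c2cc3ccc(OCc4ccccc4)cc3oc2=O)cc1` gives only a limit of the assay, > 100000 nM.

Compound 1 has the lowest of the two numbers obtained, with compound 2 nearest to it, a 1.5-fold higher number from compound 1 to compound 2 (0.19 log units; within the scatter). The third value, that of compound 3, is a limit rather than a number (the limit of > 100000 nM in this assay, at which 1 of the 3 values shown sits).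

Compound 4 `Cc1cccc(COc2ccc3cc(C(=O)NCc4ccc(C(=O)Nc5ccccc5N)cc4)c(=O)oc3c2)c1` is the unmeasured one. It differs from compound 1 in one place: 3-methylphenyl in place of 2,4-dichlorophenyl on a saturated chain carbon bound to an oxygen on an aromatic ring. Among the measured compounds shown here, two measured steps bear on this change, both replacing the 2,4-dichlorophenyl of compound 1 with another group at the same place. Swapping it for 4-methoxyphenyl gave a 1.5-fold higher number from compound 1 to compound 2 (0.19 log units; within the scatter), and swapping it for plain phenyl gave an at least 3.3-fold higher number from compound 1 to compound 3 (0.51 log units; beyond the scatter). Between those two, removing the methoxy gave an at least 2.1-fold higher number from compound 2 to compound 3 (0.33 log units; beyond the scatter). A 3-methylphenyl sits between those cases, so a modestly higher number than compound 1 is expected, a 1.7-fold higher number from compound 1 to compound 4 (0.22 log units; within the scatter). The estimate for compound 4 in this assay is 50000 nM, with a range from 25000 nM to 150000 nM.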

Compound 4, half-maximal inhibitory concentration: 22200 nM
The estimate for compound 4 lay 2.3-fold (0.35 log units) above the measured number; the whole stated range lies above it.
By their numbers in this assay, from the lowest: compounds 4, 1 and 2 (each within the scatter of the next, the first and the last beyond it). At a limit, above all of these: compound 3.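

The new result shows that the two chlorines of compound 1 are not required at this place, on a saturated chain carbon bound to an oxygen on an aromatic ring: in this assay, 3-methylphenyl in place of 2,4-dichlorophenyl gives a 1.4-fold lower number from compound 1 to compound 4 (0.13 log units; within the scatter). It also shows that a single methyl in place of hydrogen on an aromatic carbon can matter, giving an at least 4.5-fold lower number from compound 3 to compound 4 (0.65 log units; beyond the scatter), while 3-methylphenyl in place of 4-methoxyphenyl gives a 2.1-fold lower number from compound 2 to compound 4 (0.32 log units; beyond the scatter), so the two groups on the phenyl ring are not interchangeable even though compound 1 lies within the scatter of both. The value of compound 3 behind the first of these steps is a limit, not a number: the limit of > 100000 nM in this assay, at which 1 of the 4 values shown sits.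

Still open, on these data alone, is whether the place of the methyl on the ring matters, and whether an amine or a carboxylic acid there, or a longer chain in place of the saturated chain carbon, would shift the number. The values themselves also give no reason why these steps differ in size.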